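Swapping the Thiazolylamino Group for a Methylpiperazine

The compounds below may be only part of what the source reports. "The series", "measured", "known", "first", "only" and "open" are said of these compounds alone.

Of the compounds shown here, two on the shared core have been measured in a functional assay on U-937 cells (Homo sapiens) for cytotoxicity, read by MTT assay, with a stated time of 3 days; on this read-out higher numbers stand for weaker inhibition and lower numbers for stronger inhibition. Compound 1 `N#Cc1c(O)nc(SCc2nc3ccccc3[nH]2)nc1-c1ccccc1` gives 3.28 nM. Compound 2 `N#Cc1c(Nc2nccs2)nc(SCc2nc3ccccc3[nH]2)nc1-c1ccccc1`, which carries a (1,3-thiazol-2-yl)amino group in place of the hydroxy, gives 3.8 nM. For the measured compounds named here, that single change produced a 1.2-fold higher number from compound 1 to compound 2 (0.06 log units; within the scatter), so the pair cannot be ordered: compound 2 stands alongside compound 1, its only neighbour among the measured compounds, the two within the scatter of each other.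

Compound 3 `CN1CCN(c2nc(SCc3nc4ccccc4[nH]3)nc(-c3ccccc3)c2C#N)CC1` has not yet been measured. It differs from compound 2 in one place: 4-methylpiperazin-1-yl in place of (1,3-thiazol-2-yl)amino on an aromatic carbon. Going by the values given here, no measured step covers this exact exchange. Among the compounds with values here, the only step on record at the same aromatic carbon of the core, from hydroxy to (1,3-thiazol-2-yl)amino, left the number essentially unchanged, and this is the sole guide available. On that basis the author expects a 1.2-fold higher number from compound 2 to compound 3 (0.07 log units; within the scatter) in this assay, that is, no shift beyond the scatter. The estimate for compound 3 in this assay is 4.5 nM, with a range from 1.5 nM to 14 nM.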

Compound 3, half-maximal inhibitory concentration: 6.75 nM
Estimate against measurement, compound 3: 1.5-fold (0.18 log units) below, and the stated range covers the measured number.
By their numbers in this assay, from the lowest: compounds 1, 2 and 3 (each within the scatter of the next, the first and the last beyond it).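

The carbon ortho to a cyano group now carries a third kind of group, and in this assay the exchange of an aromatic five-membered ring on an amino link for the non-aromatic 4-methylpiperazin-1-yl, which has no hydrogen-bond donor, gives a 1.8-fold higher number from compound 2 to compound 3 (0.25 log units; within the scatter) and so leaves compounds 2 and 3 unordered. For the compounds shown here, measured against the hydroxy group, the same 4-methylpiperazin-1-yl gives a 2.1-fold higher number from compound 1 to compound 3 (0.31 log units; beyond the scatter) and this is the first step at this position to pass the scatter, though only modestly, so three quite different groups here span only a narrow band of numbers. Nothing on record explains that small difference.

The compounds shown leave open whether a piperazine without the methyl, a morpholine or an open-chain amine such as dimethylamino at this carbon would stay within the same narrow band, and so whether the second ring nitrogen or the methyl has any bearing on the number. They also leave open whether these exchanges would read the same way with a pyridine or a cyclohexyl group in place of the phenyl group on the shared core.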